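A few compounds are considered here, and "the series" means these few. Any claim that something is new, unique, unknown or untested is made for them only; others in the source may bear on it.

Three compounds sharing one core have been examined in a functional assay on LOX IMVI cells (Homo sapiens) for inhibition, read by sulforhodamine B assay, with a stated time of 48 h; on this read-out lower numbers stand for higher toxicity in this test and higher numbers for lower toxicity in this test. Compound 1 `CCOC(=O)[C@H](CCC(=O)O)NC(=O)c1ccc(Sc2nc3cc(N)cc(N)c3nc2-c2ccccc2)cc1` gives < 100000 nM in this assay, which is a limit of the test rather than a number. Compound 2 `Nc1cc(N)c2nc(-c3ccccc3)c(Oc3ccc(F)cc3)nc2c1` gives < 100000 nM in this assay, again a limit. Compound 3 `CCOC(=O)[C@H](CCC(=O)O)NC(=O)c1ccc(CNc2nc3cc(N)cc(N)c3nc2-c2ccccc2)cc1` gives < 100000 nM in this assay, also a limit. Compound 2 therefore stands exactly where the other two stand, at the limit of < 100000 nM in this assay, at which 3 of the 3 values shown sit, and no ordering among the three can be read from these numbers.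

Compound 4 `COc1ccc(Sc2nc3cc(N)cc(N)c3nc2-c2ccccc2)cc1` has not yet been measured. It differs from compound 2 in one place: (4-methoxyphenyl)sulfanyl in place of 4-fluorophenoxy on an aromatic carbon. Within the data shown here, no step between two measured compounds is available, so the effect of this change cannot be read from any measured pair. Among the measured compounds shown here, because the limit of < 100000 nM in this assay, at which 3 of the 3 values shown sit, is where every value so far sits, the step expected from this change, a step that the limit leaves unreadable from compound 2 to compound 4, is none beyond the scatter. Compound 4 is estimated at 50000 nM, within a range from 10000 nM to 100000 nM, most likely reported again only as a limit.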

Compound 4, concentration lethal to 50% of the cells: < 100000 nM
Compound 4: a limit, no number; the forecaster's own chance of this, stated with the estimate: 80%; the middle value is on the limit's open side.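

Among these compounds, no step from compound 2 to compound 4 can be read, because in this assay both give only a limit and not a number: the limit of < 100000 nM in this assay, at which 4 of the 4 values shown sit. The compounds shown leave open how far their actual values lie from that limit, and whether (4-methoxyphenyl)sulfanyl in place of 4-fluorophenoxy changes toxicity in this test at all.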